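Cytotoxicity notes: naphthalen-2-yl in place of nitro

The source may report more compounds than this note shows. Statements on the series, on what has been measured and on what is new or still open speak of the compounds shown alone.

Of the compounds shown here, three of the shared core have been tested in an ADME assay on Vero cells (Chlorocebus sabaeus) for cytotoxicity, read by sulforhodamine B assay, with a stated time of 72 h; a lower number here means a stronger inhibitor, a higher number a weaker inhibitor. Compound 1 `CN1Cc2ccc(OCc3ccc([N+](=O)[O-])cc3)cc2[C@@H](O)C1` gives a value that is a limit of the assay, > 50000 nM. Compound 2 `CN1Cc2ccc(OCC3CCNCC3)cc2[C@@H](O)C1` likewise reaches only a limit in this assay, > 100000 nM. Compound 3 `CN1Cc2ccc(OCCCn3ccnc3[N+](=O)[O-])cc2[C@@H](O)C1` also returns a limit, > 50000 nM. Compound 1 thus sits at the limit of > 50000 nM in this assay, at which 2 of the 3 values shown sit. Compound 2 sits at the limit of > 100000 nM in this assay, at which 1 of the 3 values shown sits. Among the measured compounds shown here, no step between two measured compounds exists in this set, so no measured step size can be stated, and no ordering among the three is possible.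

Compound 4 `CN1Cc2ccc(OCc3ccc(-c4ccc5ccccc5c4)cc3)cc2[C@@H](O)C1` has not yet been measured in this assay. It differs from compound 1 by naphthalen-2-yl in place of nitro on an aromatic carbon. With every measured value a limit, the expectation rests on the three limits alone: a step from compound 1 to compound 4 of no more than the usual scatter, with a fair chance that this assay reports only a limit again. Compound 4 is expected at 40000 nM, within 10000 nM to 100000 nM. The step this implies is estimated as an at least 1.2-fold lower number from compound 1 to compound 4 (0.09 log units; that floor lies within the scatter).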

Compound 4, half-maximal inhibitory concentration: 310 nM
Estimate against measurement, compound 4: 130-fold (2.11 log units) above; the whole stated range lies above it.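

In this assay, the aromatic carbon para to a large group turns out to be a place where one change moves the read-out: naphthalen-2-yl in place of nitro gives an at least 160-fold lower number from compound 1 to compound 4 (2.20 log units; beyond the scatter). Among the compounds shown here, compound 4 is the only compound here with a value that is a number and not a limit, so it is the first evidence that a compound of the shared core can give a measurable value in this assay. Nothing shown gives a cause for this step, which rests on a single pair of compounds.

As far as these compounds go, it remains open whether the step follows from the loss of nitro or from the arrival of the two aromatic rings of naphthalen-2-yl. Also open, from the compounds shown here alone, is how a single phenyl ring, an amine or a carboxylic acid on that carbon would read in this assay.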